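Working notes: from compound 3 to compound 4

This account rests on a few compounds, and the source may have more. Where it says the series, first, only, none or still open, it means among the compounds named here.

Values in an ADME assay on HL-60 cells (Homo sapiens) for cytotoxicity, read by MTT assay, with a stated time of 24 h; a higher number here means a weaker inhibitor, a lower number a stronger inhibitor:
- compound 1 `COc1ccc(CN(C)Cc2ccc(C3=CCCN(C)C3)cc2)cc1`: > 50000 nM, a limit
- compound 2 `CN1CCC=C(c2ccc(CN(C)Cc3ccc([N+](=O)[O-])cc3)cc2)C1`: 28000 nM
- compound 3 `CN1CCC=C(c2ccc(CN(C)Cc3ccc(Cl)cc3)cc2)C1`: > 50000 nM, a limit

Compound 3 has no number, only a limit: > 50000 nM. The same holds across the series as the limit of > 50000 nM in this assay, at which 2 of the 3 values shown sit.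

Compound 4 `CN(Cc1ccc(Cl)cc1)Cc1ccc(C2CCCN(C)C2)cc1` carries one change: a group of 7 heavy atoms (6 carbon, 1 nitrogen; one six-membered non-aromatic ring with 1 hetero atom) in place of a group of 7 heavy atoms (6 carbon, 1 nitrogen; one six-membered non-aromatic ring with 1 hetero atom), on an aromatic carbon. Here 1-methylpiperidin-3-yl enters, para to a large group.

Two measured steps reach compound 3: an at least 1.7-fold higher number from compound 2 to compound 3 (0.25 log units; that floor lies within the scatter) and a step that the two limits leave unreadable from compound 1 to compound 3. Both concern the chloro group, not the group exchanged here. No step beyond the scatter is therefore expected in this assay, and no direction can be given.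

The step expected is an at least 1.1-fold lower number from compound 3 to compound 4 (0.04 log units; that floor lies within the scatter). The estimate for compound 4 is 45000 nM, with an expected range from 20000 nM to 100000 nM.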

Compound 4, half-maximal inhibitory concentration: > 50000 nM
Compound 4: only a limit was reported (the forecaster's own chance of this, stated with the estimate: 60%); middle value at least 1.1-fold (0.04 log units) from the limit.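

In this assay, within the data shown here, compound 3 and compound 4 are both reported only as limits, so no step between them can be read. The compounds shown leave open whether 1-methylpiperidin-3-yl changes the number at all, because most values sit at one point: the limit of > 50000 nM in this assay, at which 3 of the 4 values shown sit.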